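An Added Methoxy on a Compound at the Limit

The compounds below may be only part of what the source reports. "The series", "measured", "known", "first", "only" and "open" are said of these compounds alone.

In an ADME assay on HEK293 cells (Homo sapiens) for cytotoxicity, read by luminescence, with a stated time of 72 h (on this read-out higher numbers stand for an effect only at larger amounts of compound and lower numbers for an effect already at smaller amounts), compound 1 `CCOC(=O)c1c(-c2cccc(-c3ccccc3)c2)[nH]c2cc(OC)ccc2c1=O` gives only a limit, > 22000 nM. Compound 2 `CCOC(=O)c1c(-c2cccc([N+](=O)[O-])c2)[nH]c2cc(OC)ccc2c1=O` also gives only a limit, > 22000 nM. Compound 3 `CCOC(=O)c1c(-c2cccc(-c3ccccc3)c2)[nH]c2cc(Cl)ccc2c1=O` likewise gives only a limit, > 22000 nM.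

Compound 4 `CCOC(=O)c1c(-c2cccc(-c3ccccc3)c2)[nH]c2cc(OC)c(OC)cc2c1=O` differs from compound 1 by one change: methoxy in place of hydrogen on an aromatic carbon. Within the data shown here, two measured steps bear on it, and only loosely, since neither makes the same change. Nitro in place of phenyl gives a step that the two limits leave unreadable from compound 1 to compound 2, and chloro in place of methoxy gives a step that the two limits leave unreadable from compound 1 to compound 3. Neither size can be read. Compound 1 shares the limit of > 22000 nM in this assay, at which 3 of the 3 values shown sit, with both neighbours, so no step beyond the scatter, and no direction, is expected in this assay for the added methoxy.

The expected result is a step that the limit leaves unreadable from compound 1 to compound 4, most likely reported only as a limit again. The estimate for compound 4 is 25000 nM, with an expected range from 14000 nM to 45000 nM.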

Compound 4, half-maximal effective concentration: > 22000 nM
Compound 4: no number, only a limit; the forecaster's own chance of this, stated with the estimate: 85%; the middle value lies beyond the limit too.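

In this assay, among these compounds, compound 4 gives only a limit, > 22000 nM, and compound 1 is also known only as a limit, so no step between compound 1 and compound 4 can be read. The compounds shown leave open whether the added methoxy shifts the value at all, and in which direction, since all of them share one limit: the limit of > 22000 nM in this assay, at which 4 of the 4 values shown sit.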